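The compounds below may be only part of what the source reports. "The series", "measured", "known", "first", "only" and "open" are said of these compounds alone.

Among the measured compounds shown here, compound 2 `CC1=CC[C@H](C(C)(C)NC(=S)N/N=C/c2ccc[nH]2)CC1` stands at the lower of the two numbers measured so far in a functional assay on UACC-62 cells (Homo sapiens) for inhibition, read by sulforhodamine B assay, with a stated time of 48 h (a higher number here means a weaker inhibitor of growth, a lower number a stronger inhibitor of growth), where compound 2 gives 49900 nM. For the measured compounds named here, the only other measured compound, compound 1 `COc1ccc(/C=N/NC(=S)NC(C)(C)[C@H]2CC=C(C)CC2)cc1`, gives 70400 nM in this assay. Going by the values given here, the single step between them, a 1.4-fold lower number from compound 1 to compound 2 (0.15 log units; within the scatter), exchanged one aromatic group for another on the carbon with a double bond to nitrogen and stayed within the scatter, so the two compounds cannot be told apart on these numbers.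

Compound 3 `CC1=CC[C@H](C(C)(C)NC(=S)N/N=C/c2cccs2)CC1` has not yet been measured. It differs from compound 2 in one place: thiophen-2-yl in place of 1H-pyrrol-2-yl on a carbon with a double bond to nitrogen. Among the compounds with values here, this is once more the exchange of one five-membered aromatic ring with one hetero atom for another at the same carbon, and the only measured step that bears on it is a 1.4-fold lower number from compound 1 to compound 2 (0.15 log units; within the scatter), which lay within the scatter. On that basis the expected step is a 1.0-fold higher number from compound 2 to compound 3 (0.00 log units; within the scatter), not beyond the scatter in either direction. Compound 3 is therefore estimated at 50000 nM, with a range from 20000 nM to 125000 nM.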

Compound 3, concentration for total growth inhibition: 19000 nM
For compound 3 the middle estimate is 2.6-fold (0.42 log units) above the measured one; measured number below the stated range.
By their numbers in this assay, from the lowest: compound 3; then compounds 2 and 1 (each within the scatter of the next).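

In this assay the carbon with a double bond to nitrogen now proves sensitive to the ring it carries: there is a 2.6-fold lower number from compound 2 to compound 3 (0.42 log units; beyond the scatter) and a 3.7-fold lower number from compound 1 to compound 3 (0.57 log units; beyond the scatter) for the exchange of 4-methoxyphenyl, whereas the exchange that led from 4-methoxyphenyl to 1H-pyrrol-2-yl stayed within the scatter. The step from 1H-pyrrol-2-yl to thiophen-2-yl is beyond the scatter even though both groups have 5 heavy atoms and are five-membered aromatic rings with 1 hetero atom, so ring size and heavy-atom count alone do not set the number at this position. The groups differ in sulfur for nitrogen and in their counts of hydrogen-bond donors and acceptors, but no evidence here connects either difference to the change in growth inhibition.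

The compounds shown leave open whether the step follows the sulfur atom or the loss of the ring's hydrogen-bond donor, a question that furan-2-yl, with oxygen as its hetero atom, would help to address. They also leave open whether thiophen-3-yl or a thiophen-2-yl ring carrying a chloro group would keep, extend or lose this step.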